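The source may hold more compounds than are shown below. What is called first, only, known or untested is meant among the compounds shown, and "the series" means these compounds.

In a functional assay on Molt4/C8 cells (Homo sapiens) for cytotoxicity (a lower number here means a stronger inhibitor, a higher number a weaker inhibitor), compound 2 `Cc1cccc(C)c1NC(=O)/C=C/C(=O)N1C/C(=C\c2ccccc2)C(=O)/C(=C/c2ccccc2)C1` gives 6600 nM, the highest of the three numbers, against compound 1 `COc1ccc(NC(=O)/C=C/C(=O)N2C/C(=C\c3ccc([N+](=O)[O-])cc3)C(=O)/C(=C/c3ccc([N+](=O)[O-])cc3)C2)cc1` at 940 nM and compound 3 `O=C(/C=C/C(=O)N1C/C(=C\c2ccc([N+](=O)[O-])cc2)C(=O)/C(=C/c2ccc([N+](=O)[O-])cc2)C1)Nc1ccc([N+](=O)[O-])cc1` at 430 nM. Compound 4 `COc1ccc(NC(=O)/C=C/C(=O)N2C/C(=C\c3ccccc3)C(=O)/C(=C/c3ccccc3)C2)cc1` keeps the core of compound 2 but carries 4-methoxyphenyl in place of 2,6-dimethylphenyl on an amide-type nitrogen. Among the compounds with values here, only one measured step touches this group: a 2.2-fold lower number from compound 1 to compound 3 (0.34 log units; beyond the scatter), modest and beyond the scatter, with nitro in place of methoxy on an aromatic carbon. Within the data shown here, that step sits on a different core, and no measured step removes 2,6-dimethylphenyl, so the evidence is thin. A similarly modest move to a lower number is expected, a 2.2-fold lower number from compound 2 to compound 4 (0.34 log units; beyond the scatter). For compound 4 the estimated value is 3000 nM, with an expected range of 1000 nM to 9000 nM.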

Compound 4, half-maximal inhibitory concentration: 1100 nM
Compound 4: middle estimate off by 2.7-fold (0.44 log units), on the high side, within the range that was stated.
By their numbers in this assay, from the lowest: compound 3; then compounds 1 and 4 (each within the scatter of the next); then compound 2.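

The step of a 6.0-fold lower number from compound 2 to compound 4 (0.78 log units; beyond the scatter) is the first change shown in the group on the amide-type nitrogen itself. It shows that in this assay replacing 2,6-dimethylphenyl with 4-methoxyphenyl at this position moves the number beyond the scatter. Nothing measured here accounts for that move. From the compounds shown here alone, how a plain phenyl on that nitrogen would read stays open, and with it whether the step follows from the methoxy entering or the two methyl groups leaving. Going by these compounds, whether the same swap carries over to the core of compound 1 also remains open.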